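A few compounds are considered here, and "the series" means these few. Any claim that something is new, unique, unknown or untested is made for them only; others in the source may bear on it.

Measured in an ADME assay (liver) for metabolic stability, with Liver microsome (Homo sapiens) as the target, read by LC-MS, using microsomes, tested at 0.1 uM; on this read-out higher numbers stand for fast clearance and lower numbers for slow clearance:
- compound 1 (`CN(C)CCCNc1nc(N)nc2cc(-c3ccc(C(F)(F)F)cc3)sc12`): 16.9 mL.min-1.g-1
- compound 2 (`Nc1nc(NC2CCNC2)c2sc(-c3ccc(C(F)(F)F)cc3)cc2n1`): < 11.6 mL.min-1.g-1

Compound 2 has no exact number in this assay. Its result, < 11.6 mL.min-1.g-1, is a limit of the assay, and the same limit is described by the limit of < 11.6 mL.min-1.g-1 in this assay, at which 1 of the 2 values shown sits.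

Compound 3 (`Nc1nc(N2CCC(N)CC2)c2sc(-c3ccc(C(F)(F)F)cc3)cc2n1`) has not yet been measured. It carries 4-aminopiperidin-1-yl in place of (pyrrolidin-3-yl)amino on an aromatic carbon.

Within the data shown here, the only measured step that bears on this change is an at least 1.4-fold lower number from compound 1 to compound 2 (0.16 log units; that floor lies within the scatter), which also exchanges a group on the shared core. Its floor lies within the scatter, so no step beyond the scatter is expected in this assay, and no direction can be assigned with confidence. The expected change is a step that the limit leaves unreadable from compound 2 to compound 3. Compound 3 is estimated at 11 mL.min-1.g-1, with an expected range from 6 mL.min-1.g-1 to 22 mL.min-1.g-1.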

Compound 3, intrinsic clearance in microsomes: < 11.6 mL.min-1.g-1
Compound 3 was reported as a limit; the forecaster's own chance of this, stated with the estimate: 55%; the middle value does not contradict the limit.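

In this assay, the position on the aromatic carbon next to the ring nitrogen now holds a second ring group: 4-aminopiperidin-1-yl, a six-membered non-aromatic ring, stands in place of the five-membered ring of (pyrrolidin-3-yl)amino, and compound 3 again gives a limit and not a number. Compound 2 gives a limit too, so the step between these two compounds cannot be read: the limit of < 11.6 mL.min-1.g-1 in this assay, at which 2 of the 3 values shown sit. Against the 3-(dimethylamino)propyl side chain, the record shows an at least 1.4-fold lower number from compound 1 to compound 3 (0.16 log units; that floor lies within the scatter), so no real difference from that chain is established.

As far as these compounds go, it remains open how compound 3 and compound 2 compare below the limit. From the compounds shown here alone, it is also open whether a morpholine, a carboxylic acid or a longer chain on this same aromatic carbon would also end at the limit in this assay.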